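The compounds below may be only part of what the source reports. "The series", "measured", "known", "first", "only" and "open" are said of these compounds alone.

Series notes, cytotoxicity. Within the data shown here, the three measured members share one core and differ only in the group on the saturated chain carbon bound to the amide-type nitrogen in the ring: compound 1 `CS(=O)(=O)Nc1ccc2c(c1)S(=O)(=O)N=C(C1=C(O)[C@H]3CCC[C@H]3N(Cc3ccc(C(F)(F)F)cc3)C1=O)N2`, compound 2 `CS(=O)(=O)Nc1ccc2c(c1)S(=O)(=O)N=C(C1=C(O)[C@H]3CCC[C@H]3N(Cc3cccc(C(F)(F)F)c3)C1=O)N2` and compound 3 `CS(=O)(=O)Nc1ccc2c(c1)S(=O)(=O)N=C(C1=C(O)[C@H]3CCC[C@H]3N(CC3CC3)C1=O)N2`. In an ADME assay on Huh-7 cells (Homo sapiens) for cytotoxicity, with a stated time of 72 h (a higher number here means that more compound is tolerated, a lower number that less compound is tolerated), compound 1 reaches only the limit of the assay, > 33000 nM. In this assay compound 2 likewise gives a limit, > 33000 nM. In this assay compound 3 again returns a limit, > 33000 nM. Accordingly the steps a step that the two limits leave unreadable from compound 1 to compound 2, a step that the two limits leave unreadable from compound 1 to compound 3 and a step that the two limits leave unreadable from compound 2 to compound 3 cannot be sized; the one feature they share is the limit of > 33000 nM in this assay, at which 3 of the 3 values shown sit. Compound 4 `Cc1cc(CN2C(=O)C(C3=NS(=O)(=O)c4cc(NS(C)(=O)=O)ccc4N3)=C(O)[C@H]3CCC[C@H]32)ccc1F` differs from compound 3 by 4-fluoro-3-methylphenyl in place of cyclopropyl on a saturated chain carbon bound to an amide-type nitrogen in a ring. Among the measured compounds shown here, no measured step bears readably on this change; compound 1 and compound 2, which also carry a substituted phenyl ring at this place, gave no readable number either. Compound 4 is therefore expected to sit at the limit as well, estimated at 50000 nM with a range of 25000 nM to 150000 nM. The step that the limit leaves unreadable from compound 3 to compound 4 is expected to be none beyond the scatter.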

Compound 4, half-maximal cytotoxic concentration: > 1000 nM
Compound 4: only a limit was reported; the forecaster's own chance of this, stated with the estimate: 85%; the middle value is on the limit's open side.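

In this assay compound 4 gives only a limit, > 1000 nM. Among these compounds, no step linking compound 4 with compound 1, compound 2 or compound 3 can be read. The compounds shown leave open whether the group at this place changes the half-maximal cytotoxic concentration at all.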